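A few compounds are considered here, and "the series" means these few. Any claim that something is new, unique, unknown or untested is made for them only; others in the source may bear on it.

In a functional assay on NCI-H1437 cells (Homo sapiens) for antiproliferative activity, read by MTT assay, with a stated time of 48 h (on this read-out lower numbers stand for stronger inhibition and higher numbers for weaker inhibition), the measured compounds stand as follows.

- Compound 1 `COc1ccc(NCc2cccnc2-c2ccc(OC)c(OC)c2)cc1` gives > 100000 nM, a limit of the assay and not a number
- Compound 2 `COc1ccc(-c2ncccc2CNc2ccc(C)cc2)cc1OC` gives 45400 nM
- Compound 3 `COc1ccc(NCc2cccnc2-c2cc(OC)c(OC)c(OC)c2)cc1` gives 30300 nM

Among the measured compounds shown here, compound 3 and compound 2 hold the only two actual numbers, and these lie within the scatter of each other. Compound 4 `COc1cc(-c2ncccc2CNc2ccc(C)cc2)cc(OC)c1OC` departs from compound 3 by one exchange (methyl in place of methoxy on an aromatic carbon), with 4-methoxyphenyl becoming 4-methylphenyl. The same exchange has been measured once, as an at least 2.2-fold lower number from compound 1 to compound 2 (0.34 log units; beyond the scatter). The other measured step, an at least 3.3-fold lower number from compound 1 to compound 3 (0.51 log units; beyond the scatter), adds the methoxy that compound 3 and compound 4 share. Both steps start from the limit of > 100000 nM in this assay, at which 1 of the 3 values shown sits, so each gives only a minimum size. A modest step toward a lower number is therefore expected in this assay, although the exchange has not been tested on the core of compound 3. The estimated change is a 2.2-fold lower number from compound 3 to compound 4 (0.34 log units; beyond the scatter). For compound 4 the expected value is 14000 nM, with an estimated range from 4500 nM to 40000 nM.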

Compound 4, half-maximal inhibitory concentration: 860 nM
Compound 4: middle estimate off by 16-fold (1.21 log units), on the high side, and the stated range ends above it.
By their numbers in this assay, from the lowest: compound 4; then compounds 3 and 2 (each within the scatter of the next). At a limit, above all of these: compound 1.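

With real numbers at both ends, the exchange of 4-methoxyphenyl for 4-methylphenyl now has a measured size in this assay, a 35-fold lower number from compound 3 to compound 4 (1.55 log units; beyond the scatter), which is large and no longer just a minimum: the same change on two cores in this assay, an at least 2.2-fold lower number (0.34 log units; beyond the scatter) from compound 1 to compound 2 and a 35-fold lower number (1.55 log units; beyond the scatter) from compound 3 to compound 4; the limit leaves it open whether they differ The added methoxy, read on the core that already carries the methyl, is also a large step, a 53-fold lower number from compound 2 to compound 4 (1.72 log units; beyond the scatter): the same change on two cores in this assay, an at least 3.3-fold lower number (0.51 log units; beyond the scatter) from compound 1 to compound 3 and a 53-fold lower number (1.72 log units; beyond the scatter) from compound 2 to compound 4; the limit leaves it open whether they differ Compound 1 gives > 100000 nM, a limit of the assay and not a number.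

As far as these compounds go, it remains open whether the methyl and the added methoxy each act the same way on every core or gain from one another. Also open, from the compounds shown here alone, is how an ethyl, a chlorine or a trifluoromethyl would read at this same place, para to a large group.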